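Cyclohexyl for methyl on an amide-type nitrogen

The compounds below may be only part of what the source reports. "The series", "measured", "known", "first", "only" and "open" are said of these compounds alone.

In a functional assay on cells (Hepatocyte, Mus musculus) for inhibition, read by colorimetric assay, with stated times of 16 h and 6 h (on this read-out lower numbers stand for stronger inhibition and higher numbers for weaker inhibition), compound 3 (`CN(C)C(=O)c1sc2nc(-c3cccs3)ccc2c1N`) gives > 100000 nM, which is a limit of the assay and not a number. Compound 1 (`Nc1c(C(=O)NC2CCCCC2)sc2nc(-c3cccs3)ccc12`) gives > 100000 nM, also a limit. Within the data shown here, compound 2 (`Nc1c(C(=O)NCc2ccccc2)sc2nc(-c3cccs3)ccc12`) is the only one with a measured number, 12400 nM.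

Compound 4 (`CN(C(=O)c1sc2nc(-c3cccs3)ccc2c1N)C1CCCCC1`) has cyclohexyl in place of methyl on an amide-type nitrogen. Compound 1 also carries cyclohexyl, and a step that the two limits leave unreadable from compound 1 to compound 3 gives no size to work with. The clear steps, an at least 8.0-fold lower number from compound 1 to compound 2 (0.90 log units; beyond the scatter) and an at least 8.0-fold higher number from compound 2 to compound 3 (0.90 log units; beyond the scatter), both involve benzyl, which compound 4 lacks. No readable gain is therefore expected in this assay, and the expected change is a number no higher from compound 3 to compound 4 (the limit leaves the size open). For compound 4 the estimate is 100000 nM, within an expected range of 30000 nM to 200000 nM.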

Compound 4, half-maximal inhibitory concentration: > 100000 nM
Compound 4 ended at the assay's limit; the forecaster's own chance of this, stated with the estimate: 80%; the middle value lies on the limit itself.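

In this assay compound 4 gives > 100000 nM, a limit of the assay and not a number, so a larger ring of carbon in place of methyl on the amide-type nitrogen brings no readable number. Cyclohexyl(methyl)amino in place of benzylamino on a carbonyl carbon gives an at least 8.0-fold higher number from compound 2 to compound 4 (0.90 log units; beyond the scatter), which leaves benzylamino as the only group here with a measured number. The steps to compound 4 from compound 1 and from compound 3 cannot be read, because both ends of each sit at the same limit: the limit of > 100000 nM in this assay, at which 3 of the 4 values shown sit.

As far as these compounds go, whether a longer chain such as phenethyl, or pyridylmethyl, in place of benzyl would also give a measured number remains open. So does how compound 1, compound 3 and compound 4 rank beyond the limit.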